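This account rests on a few compounds, and the source may have more. Where it says the series, first, only, none or still open, it means among the compounds named here.

Compound 1 `Cc1c(O)ccc2cc(-n3cc(-c4ccc(N(C)C)cc4)nn3)c(=O)oc12` reaches only a limit of the assay, > 100000 nM, in a functional assay on MCF7 cells (Homo sapiens) for antiproliferative activity; a higher number here means a weaker inhibitor, a lower number a stronger inhibitor. Compound 2 `Cc1c(O)ccc2cc(-n3cc(/C=C/c4ccccc4)nn3)c(=O)oc12` gives 33700 nM in this assay.

Among the measured compounds shown here, compound 2 thus holds the only real number here; the other value is a limit (the limit of > 100000 nM in this assay, at which 1 of the 2 values shown sits). For the measured compounds named here, one measured step bears on the change ahead: an at least 2.9-fold lower number from compound 1 to compound 2 (0.47 log units; beyond the scatter), where one large group replaced another at the same ring carbon. Compound 3 `Cc1c(O)ccc2cc(-n3cc(-c4c[nH]c5ccccc45)nn3)c(=O)oc12` makes a similar swap at that position: 1H-indol-3-yl in place of 2-phenylethenyl on an aromatic carbon. With a single comparison to go on, no more than a modest move in this assay is expected, in either direction. Compound 3 is estimated at 25000 nM, between 6000 nM and 100000 nM. That means an expected 1.3-fold lower number from compound 2 to compound 3 (0.13 log units; within the scatter).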

Compound 3, half-maximal inhibitory concentration: 8170 nM
Beside the measured number, compound 3's estimate is 3.1-fold (0.49 log units) above it; the measured number falls inside the stated range.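

In this assay, 1H-indol-3-yl in place of 2-phenylethenyl gives a 4.1-fold lower number from compound 2 to compound 3 (0.62 log units; beyond the scatter), so this ring carbon still responds to a change between two large groups. Set against 4-(dimethylamino)phenyl, the same group gives an at least 12-fold lower number from compound 1 to compound 3 (1.08 log units; beyond the scatter). Compound 1 stands at a limit, so that second step is only a bound: the limit of > 100000 nM in this assay, at which 1 of the 3 values shown sits.

On these data alone, whether the hydrogen-bond donor of 1H-indol-3-yl matters, or only its two-ring shape, stays open. So does how a small amine or a carboxylic acid on this carbon would read.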